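Moving a Halogen Around the Benzyl Ring of Compound 1

This account rests on a few compounds, and the source may have more. Where it says the series, first, only, none or still open, it means among the compounds named here.

In a functional assay on A-375 cells (Homo sapiens) for antiproliferative activity, read by MTT assay, with a stated time of 24 h (a higher number here means a weaker inhibitor, a lower number a stronger inhibitor), compound 1 `COc1cc(OC)c(-c2coc3cc(OCc4ccc(F)cc4)ccc3c2=O)cc1OC` gives 1720 nM, the highest of the two plain numbers shown. Compound 2 `COc1cc(OC)c(-c2coc3cc(OCc4ccc(Br)cc4)ccc3c2=O)cc1OC` gives 1000 nM, and the step of a 1.7-fold lower number from compound 1 to compound 2 (0.24 log units; within the scatter). Compound 3 `COc1cc(OC)c(-c2coc3cc(OCc4ccccc4C(F)(F)F)ccc3c2=O)cc1OC` reaches only a limit of the assay, > 10000 nM, not a number. It sits at the limit of > 10000 nM in this assay, at which 1 of the 3 values shown sits. Compound 4 `COc1cc(OC)c(-c2coc3cc(OCc4cccc(Cl)c4)ccc3c2=O)cc1OC` has not been measured; it differs from compound 1 by 3-chlorophenyl in place of 4-fluorophenyl on a saturated chain carbon bound to an oxygen on an aromatic ring. Within the data shown here, two steps bear on this: exchanging one halogen for another changed little, a 1.7-fold lower number from compound 1 to compound 2 (0.24 log units; within the scatter), whereas 2-(trifluoromethyl)phenyl in place of 4-fluorophenyl removed activity, an at least 5.8-fold higher number from compound 1 to compound 3 (0.76 log units; beyond the scatter). A chlorine at a new position is expected to shift the number only modestly, a 1.0-fold higher number from compound 1 to compound 4 (0.02 log units; within the scatter). Compound 4 is estimated at 1800 nM, between 600 nM and 6000 nM.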

Compound 4, half-maximal inhibitory concentration: 980 nM
Beside the measured number, compound 4's estimate is 1.8-fold (0.26 log units) above it; the range from low to high includes it.
By their numbers in this assay, from the lowest: compounds 4, 2 and 1 (each within the scatter of the next). At a limit, above all of these: compound 3.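

The 3-chlorophenyl group behaves like the two 4-halophenyl groups at this position, with no change beyond the scatter (a 1.8-fold lower number from compound 1 to compound 4 (0.24 log units; within the scatter)) (a 1.0-fold lower number from compound 2 to compound 4 (0.01 log units; within the scatter)). A halogen away from the 4-position therefore keeps activity, so the 2-(trifluoromethyl)phenyl group stands apart (an at least 10-fold lower number from compound 3 to compound 4 (1.00 log units; beyond the scatter)). Compound 3 remains a limit of the assay, not a number: the limit of > 10000 nM in this assay, at which 1 of the 4 values shown sits.

Whether that loss belongs to the trifluoromethyl group or to its place on the ring stays open, as no compound shown separates the two. As far as these compounds go, how an amine or a carboxylic acid on this ring would behave also remains unknown.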